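The source may report more compounds than this note shows. Statements on the series, on what has been measured and on what is new or still open speak of the compounds shown alone.

Three compounds have been measured in an assay on isolated protein for inhibition of alpha-galactosidase (Coffea arabica), tested at 1000 uM; on this read-out lower numbers stand for less inhibition and higher numbers for more inhibition at the one concentration tested (going by the name of the read-out):

compound 1, `OC[C@@]1(c2ccc(F)cc2)NC[C@@H](O)[C@@H]1O` — 0%
compound 2, `OC[C@]1(c2ccc(F)cc2)NC[C@H](O)[C@H]1O` — 0%
compound 3, `OC[C@@]1(c2c(F)c(F)c(F)c(F)c2F)NC[C@@H](O)[C@@H]1O` — 0%

Compound 1 stands level with both of its neighbours: against compound 2 the difference is no change at the digits printed from compound 1 to compound 2 (within the scatter), and compound 3 shows the same reading as compound 1. The step from compound 1 to compound 2 rests on (the fact that compounds 1 and 2 differ only in the configuration as drawn), and it leaves the reading unmoved. For the measured compounds named here, no step connects compound 1 to compound 3, so their two values are only set side by side; they coincide.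

The compound now to be examined is compound 4, `OC[C@@]1(c2ccc(O)cc2)NC[C@@H](O)[C@@H]1O`. It differs from compound 1 by hydroxy in place of fluoro on an aromatic carbon. Going by the values given here, none of the measured steps touches this position, and the only measured step, from compound 1 to compound 2, was without effect in this assay. Every measured compound sits at the same reading, so there is no slope in these data from which a direction could be taken. The expected step from compound 1 to compound 4 is therefore a number 3 percentage points higher from compound 1 to compound 4 (within the scatter), that is, none beyond the scatter. For compound 4 the estimate in this assay is 3%, with a range from 0% to 20%.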

Compound 4, a percentage reported as inhibition, at one concentration (the size of the read-out at that concentration, not a potency): 1.2%
Beside the measured number, compound 4's estimate is 1.8 percentage points above it; low and high end bracket the measured number.
By their numbers in this assay, from the lowest: compounds 1, 2, 3 and 4 (each within the scatter of the next).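

In this assay, putting hydroxy in place of fluoro on the aromatic carbon para to a group of 9 heavy atoms gives a number 1.2 percentage points higher from compound 1 to compound 4 (within the scatter). For the compounds shown here, the earlier compounds offered no measured step at this position: the one step among them changed only the configuration, and compound 3 could only be set side by side with compound 1. This step now shows that a group with 1 hydrogen-bond donor and 1 hydrogen-bond acceptor can enter where fluoro, with neither, stood without taking the reading beyond the scatter at the one concentration tested, and nothing available bears on why the reading stays there.

Whether an amine, a carboxylic acid or a longer chain at this position would move the reading beyond the scatter remains open, since all the compounds shown lie within the scatter of one another and so give no direction to follow. Also open, as far as these compounds go, is whether hydroxy at this position would read the same on the mirror-image form of the core, as fluoro does in compound 2.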